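Thiol stereocentre inversion in a mercaptoacyl dipeptide series

The source may report more compounds than this note shows. Statements on the series, on what has been measured and on what is new or still open speak of the compounds shown alone.

Measured compounds:
compound 1, `Cc1ccccc1C[C@H](CS)C(=O)N[C@@H](C)C(=O)N1CCC[C@@H]1C(=O)O`, gives 6.2 nM in an assay on isolated protein for inhibition of Neprilysin (Rattus norvegicus), read by fluorescence; on this read-out lower numbers stand for stronger inhibition and higher numbers for weaker inhibition
compound 2, `C[C@H](NC(=O)[C@@H](CS)Cc1ccc(OCc2ccccc2)cc1)C(=O)N1CCC[C@@H]1C(=O)O`, gives 40 nM in this assay
compound 3, `C[C@H](NC(=O)[C@H](Cc1ccccc1)[C@H](C)S)C(=O)N1CCC[C@H]1C(=O)O`, gives 32 nM in this assay

Among the three numbers, compound 3 stands second highest. Its nearest neighbour is compound 2, whose number is slightly higher but within the scatter, so no order between compound 2 and compound 3 can be read. Its furthest neighbour is compound 1, whose number is lower by a margin beyond the scatter; compound 1 and compound 3 differ in more than one place, so only the two values themselves are compared here.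

Compound 4, `C[C@H](NC(=O)[C@H](Cc1ccccc1)[C@@H](C)S)C(=O)N1CCC[C@H]1C(=O)O`, is not yet measured. Relative to compound 3 the change is the two compounds have the same atoms and bonds and differ only in configuration as drawn: 1 of 4 stereo elements differ; a stereocentre at a saturated chain carbon is drawn S in compound 3 and R in compound 4; the inverted centre is the saturated chain carbon that carries the thiol and the methyl group.

Within the data shown here, no pair of measured compounds differs in a single place, so no measured step exists to calibrate this change. Inversion at the thiol-bearing carbon is expected to move the number in this assay in the direction of weaker inhibition, by a step beyond the scatter but not large, with wide uncertainty in either direction.

Compound 4 is therefore estimated at 60 nM, in the range 12 nM to 300 nM, a step of a 1.9-fold higher number from compound 3 to compound 4 (0.27 log units; within the scatter) expected from the inversion.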

Compound 4, half-maximal inhibitory concentration: 182 nM
Compound 4: middle estimate off by 3.0-fold (0.48 log units), on the low side; low and high end bracket the measured number.
By their numbers in this assay, from the lowest: compound 1; then compounds 3 and 2 (each within the scatter of the next); then compound 4.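

Inversion of the saturated chain carbon that carries the thiol and the methyl group, drawn S and then R, gives in this assay a 5.7-fold higher number from compound 3 to compound 4 (0.75 log units; beyond the scatter), the first single-place step available in this series. The step lies beyond the scatter, so configuration at this carbon matters for the read-out, and in this pair the R drawing goes with weaker inhibition. The shift can be assigned to this one stereocentre alone because no atom or bond changes and no other configuration differs: the fact that compounds 3 and 4 differ only in the configuration as drawn.

From the compounds shown here alone, this is a single pair on a single core, so whether the same direction and size of step would hold on the cores of compound 1 and compound 2, which carry no methyl group on the thiol-bearing carbon, remains open. Also open, going by these compounds, is whether an ethyl group in place of the methyl group, or a carboxylic acid in place of the thiol, would leave this carbon just as sensitive to inversion in this assay.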